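From hydroxy alkene to hydroxy alkyne in the series

A few compounds are considered here, and "the series" means these few. Any claim that something is new, unique, unknown or untested is made for them only; others in the source may bear on it.

In a functional assay on L1210 cells (Mus musculus) for inhibition (a higher number here means a weaker inhibitor, a lower number a stronger inhibitor), compound 1 `Nc1ccn(C/C=C/CCl)c(=O)n1` gives 50000 nM. Compound 2 `Nc1ccn(C/C=C\CO)c(=O)n1` has no number, only a limit of the assay: > 1000000 nM. Compound 2 thus stands at the limit of > 1000000 nM in this assay, at which 1 of the 2 values shown sits.

Compound 3 `Nc1ccn(CC#CCO)c(=O)n1` differs from compound 2 by 3-hydroxyprop-1-yn-1-yl in place of 3-hydroxyprop-1-en-1-yl on a saturated chain carbon bound to an aromatic nitrogen.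

Going by the values given here, only one measured step bears on this change, and it is large: an at least 20-fold higher number from compound 1 to compound 2 (1.30 log units; beyond the scatter). Among the compounds with values here, that step puts 3-hydroxyprop-1-en-1-yl in place of 3-chloroprop-1-en-1-yl, and no measured step exchanges a double bond for a triple bond. Compound 3 keeps the hydroxy end reached in an at least 20-fold higher number from compound 1 to compound 2 (1.30 log units; beyond the scatter), so no step beyond the scatter is expected in this assay, and a report as a limit is likely.

The estimated change is a number no higher from compound 2 to compound 3 (the limit leaves the size open), a rough expectation given that its starting point is a limit. For compound 3 the expected value is 1000000 nM, with an estimated range of 250000 nM to 2000000 nM.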

Compound 3, half-maximal inhibitory concentration: > 550000 nM
Compound 3: a limit, no number; the forecaster's own chance of this, stated with the estimate: 65%; the middle value is on the limit's open side.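

In this assay, compound 3 is reported only as a limit, > 550000 nM, not as a number. Replacing 3-chloroprop-1-en-1-yl with 3-hydroxyprop-1-yn-1-yl still gives a readable result: an at least 11-fold higher number from compound 1 to compound 3 (1.04 log units; beyond the scatter). The series now holds two hydroxy-ended compounds, one with a double bond and one with a triple bond, and both lie beyond the scatter from the chloro-ended compound 1, so the large weakening seen with the hydroxy end in compound 2 is not confined to the double-bonded chain; the step between compound 2 and compound 3 cannot be read, since both values are limits.

The compounds shown therefore give no size for the exchange of double bond for triple bond at this position on a saturated chain carbon bound to an aromatic nitrogen, and they do not separate the contribution of the chain's end group from that of its unsaturated link. A 3-chloroprop-1-yn-1-yl group, or an amine at the end of the same chain, would test whether a measurable number in this assay depends on the chlorine or is open to other end groups.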